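Adding a Methyl to a Hydroxy Oxygen

A few compounds are considered here, and "the series" means these few. Any claim that something is new, unique, unknown or untested is made for them only; others in the source may bear on it.

In a functional assay on NCI-H226 cells (Homo sapiens) for antiproliferative activity, read by sulforhodamine B assay, with a stated time of 48 h (a higher number here means a weaker inhibitor of growth, a lower number a stronger inhibitor of growth), compound 1 (`O=C(NCCCNc1cc(-c2cn(-c3ccccc3)nc2-c2cccc(O)c2)ccn1)Nc1ccc(F)cc1`) gives 8910 nM and compound 2 (`O=C(NCCCNc1cc(-c2cn(-c3ccccc3)nc2-c2cccc(O)c2)ccn1)Nc1cccc(C(F)(F)F)c1`) gives 11500 nM and these two values lie within the scatter of each other. Compound 3 (`COc1cccc(-c2nn(-c3ccccc3)cc2-c2ccnc(NCCCNC(=O)Nc3ccc(F)cc3)c2)c1`) differs from compound 1 by one change (methyl in place of hydrogen on an oxygen on an aromatic ring) that turns hydroxy to methoxy. Among the measured compounds shown here, the only measured step (a 1.3-fold higher number from compound 1 to compound 2 (0.11 log units; within the scatter)) lies within the scatter and leaves that oxygen untouched, so the data offer no direct guide to this change. The expected step (a 1.1-fold higher number from compound 1 to compound 3 (0.05 log units; within the scatter)) therefore stays within the scatter. The estimated value for compound 3 is 10000 nM with a range from 4500 nM to 25000 nM around it.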

Compound 3, concentration for total growth inhibition: > 37000 nM
Compound 3 gave a limit, no number; the forecaster's own chance of this, stated with the estimate: 8%; middle value at least 3.7-fold (0.56 log units) from the limit.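

Unlike the earlier change on an amide-type nitrogen, turning hydroxy into methoxy clearly shifts the read-out: an at least 4.1-fold higher number from compound 1 to compound 3 (0.61 log units; beyond the scatter). The hydrogen on this oxygen therefore matters in this assay, and putting methyl there leaves compound 3 a weaker inhibitor of growth than compound 1. The step rests on a limit rather than a number, so its full size stays unknown: the limit of > 37000 nM in this assay, at which 1 of the 3 values shown sits.

From the compounds shown here alone, whether removing the hydrogen or adding the carbon drives the shift remains open. An amine in place of the hydroxy, or a longer ethoxy chain on the oxygen, could separate the two.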